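From Acetyl to Chloro on the Aromatic Ring

The compounds below may be only part of what the source reports. "The series", "measured", "known", "first", "only" and "open" are said of these compounds alone.

Compound 1 `CC1(C)CCCC2=CC=C(C=O)CC[C@]21C` gives 191000 nM in a functional assay on DU-145 cells (Homo sapiens) for cytotoxicity, read by MTT assay, with a stated time of 48 h; on this read-out higher numbers stand for weaker inhibition and lower numbers for stronger inhibition
Compound 2 `C#CC1=CC[C@@]2(C)C(=C)CCC[C@]2(C)CC1` gives 387000 nM in this assay
Compound 3 `C=C1CCC[C@]2(C)CCC(c3cn(-c4ccc(C(C)=O)cc4)nn3)=CC[C@@]12C` gives 51700 nM in this assay

Compound 3 has the lowest number of the three, and its gaps to compound 1 and compound 2 lie beyond the scatter. Compound 4 `C=C1CCC[C@]2(C)CCC(c3cn(-c4ccc(Cl)cc4)nn3)=CC[C@@]12C` carries chloro in place of acetyl on an aromatic carbon, para to a large group (chloro in place of acetyl on an aromatic carbon). Among the measured compounds shown here, no measured pair differs in one place, so the data offer no direct precedent. Apart from this group compound 4 matches compound 3, so the expectation stays anchored on compound 3 at 51700 nM and foresees no step beyond the scatter in this assay for this change. The estimated move a 1.1-fold lower number from compound 3 to compound 4 (0.06 log units; within the scatter) is slightly downward at most. Compound 4 is expected at 45000 nM within an estimated span from 18000 nM to 110000 nM as its range.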

Compound 4, half-maximal inhibitory concentration: 26000 nM
Beside the measured number, compound 4's estimate is 1.7-fold (0.24 log units) above it, within the range that was stated.
By their numbers in this assay, from the lowest: compounds 4 and 3 (each within the scatter of the next); then compound 1; then compound 2.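

Among the compounds shown here, the pair gives the first comparison in one place: in this assay, chloro in place of acetyl on an aromatic carbon, para to a large group, gives a 2.0-fold lower number from compound 3 to compound 4 (0.30 log units; within the scatter) on the shared core. The acetyl group is therefore not required to hold the number at this position, since 4-acetylphenyl and 4-chlorophenyl cannot be told apart on this read-out. No measurement shown here bears on why the two read alike. Going by these compounds, whether an amine, a carboxylic acid or a longer chain at this place would do the same remains open.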